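The source may hold more compounds than are shown below. What is called first, only, known or untested is meant among the compounds shown, and "the series" means these compounds.

In a functional assay on MIA PaCa-2 cells (Homo sapiens) for inhibition, read by MTT assay, with a stated time of 3 days (a lower number here means a stronger inhibitor, a higher number a weaker inhibitor), compound 1 `CCN(CC)S(=O)(=O)c1ccc(S(=O)(=O)N2CCC[C@@H](C(=O)NC3CN(C(=O)OC(C)(C)C)C3)C2)cc1` gives 100 nM. Compound 3 `CCOC(=O)[C@@H]1CCCN(S(=N)(=O)c2ccc(S(=O)(=O)N(CC)CC)cc2)C1` gives 4700 nM in this assay, a gap from compound 1 that lies beyond the scatter. Compound 2 `CCOC(=O)N1CCC[C@H](S(=O)(=O)c2ccc(S(=O)(=O)N(CC)CC)cc2)C1` reaches only a limit of this assay, > 10000 nM. That limit is the limit of > 10000 nM in this assay, at which 1 of the 3 values shown sits. Among the numbers shown, compound 1 therefore stands lowest. Compound 4 `CCN(CC)S(=O)(=O)c1ccc(S(=O)(=O)N2CCC[C@@H](C(=O)NC3CN(C(=O)NC(C)(C)C)C3)C2)cc1` differs from compound 1 in one place: (tert-butyl)amino in place of tert-butoxy on a carbonyl carbon. For the measured compounds named here, no measured pair shows this exchange, so the expectation rests on compound 1 alone at 100 nM, with a small expected step in this assay, a 1.5-fold higher number from compound 1 to compound 4 (0.18 log units; within the scatter), as likely either way or none beyond the scatter. Compound 4 is thus expected near 150 nM, between 50 nM and 500 nM.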

Compound 4, half-maximal inhibitory concentration: 1400 nM
Compound 4: middle estimate off by 9.3-fold (0.97 log units), on the low side; measured number outside the range, above it.
By their numbers in this assay, from the lowest: compound 1; then compound 4; then compound 3. At a limit, above all of these: compound 2.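

Exchanging tert-butoxy for (tert-butyl)amino on this carbonyl carbon gives a 14-fold higher number from compound 1 to compound 4 (1.15 log units; beyond the scatter) in this assay. The position therefore responds strongly to a change that keeps the heavy-atom count the same, replacing an oxygen with a nitrogen that brings a hydrogen-bond donor. Nothing measured here gives a reason for this step.

Still open, going by these compounds, is how an ethoxy or isopropoxy group on this carbonyl carbon would compare with tert-butoxy, and whether a methylamino group would follow (tert-butyl)amino.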